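A few compounds are considered here, and "the series" means these few. Any claim that something is new, unique, unknown or untested is made for them only; others in the source may bear on it.

Measured compounds:
Compound 1, `COc1ccc(-c2cc3[nH]nc(-c4cc(OC)c(OC)c(OC)c4)n3n2)cc1[N+](=O)[O-]`, gives 58200 nM in a functional assay on A549 cells (Homo sapiens) for antiproliferative activity, read by MTT assay, with a stated time of 72 h; on this read-out lower numbers stand for stronger inhibition and higher numbers for weaker inhibition.
Compound 2, `COc1ccc(-c2nn3c(-c4ccc(OC)c(OC)c4)nnc3s2)cc1N`, gives 522 nM in this assay.
Compound 3, `COc1cccc(-c2nnc3sc(-c4ccc(OC)c(N)c4)nn23)c1`, gives 120 nM in this assay.

Compound 3 has the lowest number of the three measured compounds. Its nearest neighbour is compound 2, whose number lies beyond the scatter above it; compound 1 lies far higher still.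

Compound 4, `COc1ccc(-c2nnc3sc(-c4ccc(OC)c(N)c4)nn23)cc1`, has not yet been measured. It differs from compound 3 in one place: 4-methoxyphenyl in place of 3-methoxyphenyl on an aromatic carbon. Within the data shown here, only one measured step touches this part of the molecules, a 4.4-fold lower number from compound 2 to compound 3 (0.64 log units; beyond the scatter), and that step concerns hydrogen in place of methoxy, not a shift of the methoxy group to another position on the ring. Among the measured compounds shown here, no measured pair isolates the move from 3-methoxyphenyl to 4-methoxyphenyl, so its direction cannot be read from the data. Compound 2, which carries methoxy at both positions, sits above compound 3, and the one-ring rearrangement in compound 4 is expected to shift the number only modestly, more likely upward than downward. Compound 4 is therefore estimated at 250 nM, with a range from 80 nM to 800 nM, which corresponds to an expected step of a 2.1-fold higher number from compound 3 to compound 4 (0.32 log units; beyond the scatter).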

Compound 4, half-maximal inhibitory concentration: 14900 nM
Estimate against measurement, compound 4: 60-fold (1.78 log units) below; measured number outside the range, above it.
By their numbers in this assay, from the lowest: compound 3; then compound 2; then compound 4; then compound 1.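

In this assay, among these compounds, the aryl group on the aromatic carbon between two ring nitrogen atoms proves far more sensitive to where its methoxy group sits than the earlier compounds could show: a simple shift from 3-methoxyphenyl to 4-methoxyphenyl gives a 120-fold higher number from compound 3 to compound 4 (2.09 log units; beyond the scatter), although the two groups have the same atoms. Compound 2 carries methoxy at both ring positions, and the two single removals from it go in opposite directions, with a 4.4-fold lower number from compound 2 to compound 3 (0.64 log units; beyond the scatter) when the 3-methoxyphenyl group remains and a 29-fold higher number from compound 2 to compound 4 (1.46 log units; beyond the scatter) when the 4-methoxyphenyl group remains, so among these three compounds the 3-methoxyphenyl group gives the lowest number and the 4-methoxyphenyl group the highest. Nothing available explains this difference between the two positions.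

The compounds shown leave open whether the methoxy group itself matters at the position it holds in compound 3, or whether another group there, such as hydroxyl, ethoxy or an amine, would give a similar number. They also leave open where an unsubstituted phenyl or a 2-methoxyphenyl group at this carbon would fall relative to compound 3 and compound 4.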